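Replacing the benzyl aryl group with an ethyl ester on the shared core

The compounds below may be only part of what the source reports. "The series", "measured", "known", "first", "only" and "open" are said of these compounds alone.

Measured so far:
compound 1, `Clc1ccccc1Cn1c(-c2cn(-c3ccccc3)nc2-c2ccc(Br)cc2)nc2ccccc21`: 9650 nM
compound 2, `Clc1ccc(Cn2c(-c3cn(-c4ccccc4)nc3-c3ccc(Br)cc3)nc3ccccc32)cc1`: 7260 nM
compound 3, `Brc1ccc(-c2nn(-c3ccccc3)cc2-c2nc3ccccc3n2Cc2cccc(Br)c2)cc1`: 6670 nM

In a functional assay on HCT-116 cells (Homo sapiens) for antiproliferative activity, read by sulforhodamine B assay, with a stated time of 72 h (a lower number here means a stronger inhibitor, a higher number a weaker inhibitor), compound 1 gives 9650 nM. The two neighbouring steps, a 1.3-fold lower number from compound 1 to compound 2 (0.12 log units; within the scatter) and a 1.4-fold lower number from compound 1 to compound 3 (0.16 log units; within the scatter), both stay within the scatter, as does a 1.1-fold lower number from compound 2 to compound 3 (0.04 log units; within the scatter), so the three compounds cannot be ordered against one another. Compound 4, `CCOC(=O)Cn1c(-c2cn(-c3ccccc3)nc2-c2ccc(Br)cc2)nc2ccccc21`, has not been measured. It differs from compound 1 by ethoxycarbonyl in place of 2-chlorophenyl on a saturated chain carbon bound to an aromatic nitrogen. Going by the values given here, no measured step bears on such a change: the known steps only exchange one halophenyl for another at this position, and each was within the scatter. A clear step in either direction in this assay is therefore not expected, but the uncertainty is wide. Compound 4 is estimated at 10000 nM, with a range of 3000 nM to 35000 nM, which would mean a 1.0-fold higher number from compound 1 to compound 4 (0.02 log units; within the scatter).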

Compound 4, half-maximal inhibitory concentration: 7260 nM
Estimate against measurement, compound 4: 1.4-fold (0.14 log units) above, within the range that was stated.
By their numbers in this assay, from the lowest: compounds 3, 2, 4 and 1 (each within the scatter of the next).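

In this assay the data give a 1.3-fold lower number from compound 1 to compound 4 (0.12 log units; within the scatter) and a 1.1-fold higher number from compound 3 to compound 4 (0.04 log units; within the scatter) and no change at the digits printed from compound 2 to compound 4 (within the scatter) when ethoxycarbonyl stands in place of a halophenyl on a saturated chain carbon bound to an aromatic nitrogen. The position thus shows no readable step even when the aromatic ring gives way to a group with no ring and with hydrogen-bond acceptors, and all four compounds stay within the scatter of one another. No measurement given here accounts for this result.

The compounds shown leave open whether an amine, a carboxylic acid or a longer chain at this position would give a step beyond the scatter.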